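Benzyl-triazole aryl ethers: cytotoxicity at the assay limit

The source may hold more compounds than are shown below. What is called first, only, known or untested is meant among the compounds shown, and "the series" means these compounds.

Compound 1 `O=c1ccoc2cc(OCc3cn(Cc4ccccc4)nn3)ccc12`: in a functional assay on MDA-MB-231 cells (Homo sapiens) for cytotoxicity, read by MTT assay, with a stated time of 48 h (a lower number here means a stronger inhibitor, a higher number a weaker inhibitor), compound 1 gives > 100000 nM, a limit of the assay.
Compound 2 `Cc1ccc(Cn2cc(COc3ccc4c(=O)ccoc4c3)nn2)cc1`: in this assay compound 2 gives > 100000 nM, again only a limit.
Compound 3 `Cc1ccccc1Cn1cc(COc2ccc3c(=O)ccoc3c2)nn1`: in this assay compound 3 gives > 100000 nM, also a limit.

Compound 2 therefore stands at the assay limit, as do the other two values shown (the limit of > 100000 nM in this assay, at which 3 of the 3 values shown sit). Compound 4 `O=c1ccoc2cc(OCc3cn(Cc4ccc([N+](=O)[O-])cc4)nn3)ccc12` differs from compound 2 by nitro in place of methyl on an aromatic carbon.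

The measured steps that come closest are the methyl additions a step that the two limits leave unreadable from compound 1 to compound 2 and a step that the two limits leave unreadable from compound 2 to compound 3, both unreadable because each end sits at a limit. No readable step is available, so no movement beyond the scatter is expected in this assay and a further limit is the likeliest outcome.

Compound 4 is expected to give 150000 nM, within 40000 nM to 600000 nM. The expected step is a step that the limit leaves unreadable from compound 2 to compound 4.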

Compound 4, half-maximal inhibitory concentration: 71300 nM
Beside the measured number, compound 4's estimate is 2.1-fold (0.32 log units) above it; measured number inside the range.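

Nitro in place of methyl, para to a large group, gives the only number in this assay that is not a limit, with an at least 1.4-fold lower number from compound 2 to compound 4 (0.14 log units; that floor lies within the scatter). The comparisons with the other two compounds read alike, with an at least 1.4-fold lower number from compound 3 to compound 4 (0.14 log units; that floor lies within the scatter) and an at least 1.4-fold lower number from compound 1 to compound 4 (0.14 log units; that floor lies within the scatter). These steps are floors and not sizes, because the other three compounds sit at a limit: the limit of > 100000 nM in this assay, at which 3 of the 4 values shown sit.

On these data alone, whether the change carries any real shift beyond the scatter remains open. Also open, as far as these compounds go, is how an amine, a carboxylic acid or trifluoromethyl at the same place would read in this assay.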